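The compounds below may be only part of what the source reports. "The series", "measured", "known", "first", "only" and "open" are said of these compounds alone.

Compound 1 `CCNC(=O)c1nc(-c2ccc(CN(C)C)cc2)cnc1N`, compound 2 `CN(C)Cc1ccc(-c2cnc(N)c(C(=O)NC3CCC(O)CC3)n2)cc1`, compound 3 `CCN(CC)Cc1ccc(-c2cnc(N)c(C(=O)NC[C@@](C)(O)C(F)(F)F)n2)cc1`.

In a physicochemical assay for solubility, at pH 6.8 (a lower number here means a less soluble compound, a higher number a more soluble compound), compound 1 gives > 1000000 nM, which is a limit of the assay rather than a number. Compound 2 gives 850000 nM. Compound 3 gives > 1000000 nM, again a limit. Compound 1 therefore stands at the limit of > 1000000 nM in this assay, at which 2 of the 3 values shown sit.

Compound 4 `CN(C)Cc1ccc(-c2cnc(N)c(C(=O)NCC(O)C(F)(F)F)n2)cc1` differs from compound 1 by 2,2,2-trifluoro-1-hydroxyethyl in place of methyl on a saturated chain carbon bound to an amide-type nitrogen. Going by the values given here, the only measured step, an at least 1.1-fold lower number from compound 1 to compound 2 (0.07 log units; that floor lies within the scatter), changes the same amide substituent and stays within the scatter. Compound 3, carrying a related 3,3,3-trifluoro-2-hydroxypropyl group, also sits at the limit. No step beyond the scatter is therefore expected. Compound 4 is expected to give 1000000 nM, between 500000 nM and 2000000 nM. The expected step is a number no higher from compound 1 to compound 4 (the limit leaves the size open).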

Compound 4, solubility: 880000 nM
For compound 4 the middle estimate is 1.1-fold (0.06 log units) above the measured one, and the stated range covers the measured number.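

In this assay, the change to a 3,3,3-trifluoro-2-hydroxypropyl group on the amide-type nitrogen gives an at least 1.1-fold lower number from compound 1 to compound 4 (0.05 log units; that floor lies within the scatter). Compound 1 stands at a limit, not a number, so only that floor can be read: the limit of > 1000000 nM in this assay, at which 2 of the 4 values shown sit. Against the 4-hydroxycyclohexyl group, the same chain gives a 1.0-fold higher number from compound 2 to compound 4 (0.02 log units; within the scatter), showing that these two quite different substituents read alike at this position.

From the compounds shown here alone, what remains open is whether a plain 2-hydroxypropyl chain, without fluorine, would read the same. Going by these compounds, whether a carboxylic acid or an amine on this chain would give a step beyond the scatter is also open.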